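The compounds below may be only part of what the source reports. "The series", "measured", "known", "first", "only" and "open" are said of these compounds alone.

Working notes on the series.

The shared core carries a substituent on the aromatic ring bearing the pyridin-4-yl group; three compounds with a number in an assay for inhibition of cholesterol 24-hydroxylase (Homo sapiens), using NADPH, with stated times of 15 min and 5 min (a lower number here means a stronger inhibitor, a higher number a weaker inhibitor), are in hand. Compound 1 `Cc1cccc(-c2ccncc2)c1C(=O)N1CCC(O)(Cc2ccccc2)CC1` gives 7.8 nM in this assay. Compound 2 `O=C(c1cc(Cl)ccc1-c1ccncc1)N1CCC(O)(Cc2ccccc2)CC1` gives 2.4 nM in this assay. Compound 3 `COc1ccc(-c2ccncc2)c(C(=O)N2CCC(O)(Cc3ccccc3)CC2)c1` gives 4.7 nM in this assay, which leaves compound 3 with the second highest of the three numbers, within the scatter of both compound 1 and compound 2.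

For the measured compounds named here, the one measured step at the same place is a 2.0-fold higher number from compound 2 to compound 3 (0.29 log units; within the scatter), a change that does not rise above the scatter. Compound 1 differs at another place and bears on the question only through its value.

Compound 4 `O=C(c1cc(F)ccc1-c1ccncc1)N1CCC(O)(Cc2ccccc2)CC1` is not yet measured. It differs from compound 3 by fluoro in place of methoxy on an aromatic carbon. Since the step from chloro to methoxy gave a 2.0-fold higher number from compound 2 to compound 3 (0.29 log units; within the scatter), the exchange of methoxy for fluoro is expected to produce no step beyond the scatter, a 1.2-fold lower number from compound 3 to compound 4 (0.07 log units; within the scatter). Compound 4 is therefore estimated at 4 nM in this assay, with a range from 1.5 nM to 11 nM.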

Compound 4, half-maximal inhibitory concentration: 6.1 nM
For compound 4 the middle estimate is 1.5-fold (0.18 log units) below the measured one, within the range that was stated.
By their numbers in this assay, from the lowest: compounds 2, 3, 4 and 1 (each within the scatter of the next, the first and the last beyond it).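

At this position, the aromatic carbon para to a pyridin-4-yl group, the exchange of methoxy for fluoro gives a 1.3-fold higher number from compound 3 to compound 4 (0.11 log units; within the scatter) in this assay, so these two groups are not separated. The exchange of chloro for fluoro gives a 2.5-fold higher number from compound 2 to compound 4 (0.41 log units; beyond the scatter), a modest step and the only one at this position beyond the scatter, which shows that the position can register a change of substituent even though the step from chloro to methoxy alone did not. No evidence at hand bears on the size of either step.

For the compounds shown here, with three substituents at this position, the one separated pair rests on a modest step and shows no general trend. As far as these compounds go, whether a nitrile, trifluoromethyl or an amine on the same carbon would stay within the scatter of these values or move beyond it remains open.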